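The source may report more compounds than this note shows. Statements on the series, on what has been measured and on what is new or still open speak of the compounds shown alone.

Of the compounds shown here, two have been measured so far in an assay on HEK293 cells for displacement of a labelled ligand from Melanocortin receptor 4 (Homo sapiens); a lower number here means a stronger inhibitor, a higher number a weaker inhibitor. Compound 1 `CCC(C)[C@H](NC(=O)OC)c1cc(C(F)(F)F)ccc1N1CCN(C(=O)CCc2ccc(Cl)cc2Cl)CC1` gives 2400 nM in this assay. Compound 2 `CCC(C)[C@H](NC(C)=O)c1cc(C(F)(F)F)ccc1N1CCN(C(=O)CCc2ccc(Cl)cc2Cl)CC1` gives 360 nM in this assay, the lowest of the two numbers. Within the data shown here, the only measured step, a 6.7-fold lower number from compound 1 to compound 2 (0.82 log units; beyond the scatter), shows that exchanging one small group for another on a carbonyl carbon can move the number by a modest amount. Compound 3 `CCC(C)[C@H](NC(=O)CN)c1cc(C(F)(F)F)ccc1N1CCN(C(=O)CCc2ccc(Cl)cc2Cl)CC1` differs from compound 2 by amino in place of hydrogen on a saturated chain carbon bound to a carbonyl carbon. Among the measured compounds shown here, no measured step covers an amino group at this place; the step of a 6.7-fold lower number from compound 1 to compound 2 (0.82 log units; beyond the scatter) concerns a different exchange on the same carbonyl carbon and offers only a hint that this region tolerates change. Without a direct precedent, compound 3 is expected to land near compound 2. The expected step of a 1.4-fold higher number from compound 2 to compound 3 (0.14 log units; within the scatter) is therefore small, within or just beyond the scatter. For compound 3 the estimate in this assay is 500 nM, with a range from 150 nM to 1700 nM.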

Compound 3, inhibition constant: 18 nM
Compound 3: the middle estimate sits 28-fold (1.44 log units) above what was measured; measured number outside the range, below it.
By their numbers in this assay, from the lowest: compound 3; then compound 2; then compound 1.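

In this assay, among these compounds, a single amino group in place of hydrogen on the saturated chain carbon bound to a carbonyl carbon brings a 20-fold lower number from compound 2 to compound 3 (1.30 log units; beyond the scatter), a large step where the only earlier exchange at this end of the molecule was modest. Aminomethyl in place of methoxy on the carbonyl carbon gives a 130-fold lower number from compound 1 to compound 3 (2.12 log units; beyond the scatter), so the small group carried on this carbonyl carbon can move the number widely while the shared core stays the same. Nothing measured here explains why the amino group has this effect.

The compounds shown leave open whether the change is specific to this amino group or would also appear with a hydroxyl group, a dimethylamino group or a longer chain ending in an amine. They also leave open how a carboxylic acid at the same place would move the number.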